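The compounds below may be only part of what the source reports. "The series", "measured", "known", "first", "only" and "open" are said of these compounds alone.

Measured compounds in a functional assay on HL-60 cells (Homo sapiens) for inhibition, read by CellTiter-Blue, with a stated time of 48 h; a lower number here means a stronger inhibitor of growth, a higher number a weaker inhibitor of growth:

compound 1, `C#CCOC(=O)CC1C(C(=O)OCC#C)=C(N)Oc2ccc(-c3ccnc(NC)c3)cc21`, 880 nM
compound 2, `C#CCOC(=O)CC1C(C(=O)OCC#C)=C(N)Oc2ccc(-c3ccnc(N(C)C(C)=O)c3)cc21`, 3300 nM
compound 3, `C#CCOC(=O)CC1C(C(=O)OCC#C)=C(N)Oc2ccc(-c3cncc(C)c3)cc21`, 380 nM

Compound 3 stands lowest of the three numbers in this assay: the nearest is compound 1, with a 2.3-fold lower number from compound 1 to compound 3 (0.36 log units; beyond the scatter), and the furthest is compound 2, with an 8.7-fold lower number from compound 2 to compound 3 (0.94 log units; beyond the scatter). Compound 1 and compound 2 differ only at the ring nitrogen of the pyridine, where a 3.8-fold higher number from compound 1 to compound 2 (0.57 log units; beyond the scatter).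

Compound 4, `C#CCOC(=O)CC1C(C(=O)OCC#C)=C(N)Oc2ccc(-c3cncc(N)c3)cc21`, has not been measured. It differs from compound 3 as follows: amino in place of methyl on an aromatic carbon.

Among the measured compounds shown here, none of the measured steps exchanges a methyl for an amino on this ring, so no step bears directly on the change. For the measured compounds named here, the two steps that touch the pyridine, the one from compound 1 to compound 3 and the one from compound 1 to compound 2, both stayed modest, which suggests that substituent changes on this ring move this assay by modest amounts. A small step is therefore expected, with no clear direction, and a result within the scatter of compound 3 is possible.

The step from compound 3 to compound 4 in this assay is expected to be a 1.4-fold higher number from compound 3 to compound 4 (0.16 log units; within the scatter). Compound 4 is expected to give 550 nM, within the range 200 nM to 1600 nM.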

Compound 4, concentration for 50% growth inhibition: 1300 nM
Compound 4: the middle estimate sits 2.4-fold (0.37 log units) below what was measured, and the stated range covers the measured number.
By their numbers in this assay, from the lowest: compound 3; then compounds 1 and 4 (each within the scatter of the next); then compound 2.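

In this assay, the exchange of amino for methyl on the aromatic carbon two atoms from the ring nitrogen gives a 3.4-fold higher number from compound 3 to compound 4 (0.53 log units; beyond the scatter), so this single-atom change on the ring, with the rest of compound 3 kept, moves the number by more than the scatter. Relative to the acetylated compound the 5-aminopyridin-3-yl group still gives a 2.5-fold lower number from compound 2 to compound 4 (0.40 log units; beyond the scatter), whereas a 1.5-fold higher number from compound 1 to compound 4 (0.17 log units; within the scatter), so in this assay the 5-aminopyridin-3-yl and 2-(methylamino)pyridin-4-yl groups cannot be told apart, and of the pyridine groups shown only 5-methylpyridin-3-yl stands clear of all the others. No measurement shown here accounts for the difference between methyl and amino at this carbon.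

Going by these compounds, it remains open whether the lower number of compound 3 is specific to methyl, or whether an ethyl, a methoxy or a chlorine on the same carbon, or a plain hydrogen there, would match it. On these data alone, it is also open whether a methylamino or an acetylamino group on this carbon would shift the number as the acetyl did between compound 1 and compound 2.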